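Aryl swap at the shared core: naphthyl back to aminophenyl

The source may report more compounds than this note shows. Statements on the series, on what has been measured and on what is new or still open speak of the compounds shown alone.

Two compounds of the series have numbers in a functional assay on HeLa cells (Homo sapiens) for cytotoxicity, read by MTT assay, with a stated time of 48 h; on this read-out lower numbers stand for stronger inhibition and higher numbers for weaker inhibition. Compound 1 `Cc1nc2c3ccccc3ccc2c2nc3c(ccc4ccccc43)c(-c3nccnc3N)c12` carries 3-aminopyrazin-2-yl on the shared core, and in this assay compound 1 gives 1210 nM. Compound 2 `Cc1nc2c3ccccc3ccc2c2nc3c(ccc4ccccc43)c(-c3cccc4ccccc34)c12` carries naphthalen-1-yl at the same carbon, and in this assay compound 2 gives 14900 nM. Going by the values given here, the single measured step, a 12-fold higher number from compound 1 to compound 2 (1.09 log units; beyond the scatter), places compound 2 at the highest of the two numbers, with compound 1 as its only neighbour.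

Compound 3 `Cc1nc2c3ccccc3ccc2c2nc3c(ccc4ccccc43)c(-c3ccccc3N)c12` is the next member: 2-aminophenyl in place of naphthalen-1-yl on an aromatic carbon. Among the compounds with values here, only one measured step bears on this change, a 12-fold higher number from compound 1 to compound 2 (1.09 log units; beyond the scatter), which was large when an amino-bearing ring gave way to naphthalen-1-yl. The move to compound 3 runs the other way, bringing back a ring with one hydrogen-bond donor and one acceptor, though a ring of carbon only rather than the pyrazine of compound 1, so a full return to the number of compound 1 is not assumed. A lower number is therefore expected for compound 3, a step of a 5.0-fold lower number from compound 2 to compound 3 (0.70 log units; beyond the scatter) beyond the scatter. The estimate for compound 3 is 3000 nM, within the range 1000 nM to 10000 nM.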

Compound 3, half-maximal inhibitory concentration: 16200 nM
Compound 3: middle estimate off by 5.4-fold (0.73 log units), on the low side, outside the stated range (above it).
By their numbers in this assay, from the lowest: compound 1; then compounds 2 and 3 (each within the scatter of the next).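

In this assay, a 1.1-fold higher number from compound 2 to compound 3 (0.04 log units; within the scatter) means that 2-aminophenyl and naphthalen-1-yl cannot be told apart at this aromatic carbon, opposite the ring nitrogen, although one brings a hydrogen-bond donor and acceptor and the other brings neither. The difference that stands beyond the scatter is a 13-fold higher number from compound 1 to compound 3 (1.13 log units; beyond the scatter), and since 3-aminopyrazin-2-yl and 2-aminophenyl both carry an amino group, that group alone does not set compound 1 apart within these three compounds. Nothing measured here gives a reason for the gap between the pyrazine ring and the carbon-only ring.

Still open, from the compounds shown here alone, is whether both ring nitrogens of the pyrazine are needed, a question that 3-aminopyridin-2-yl, with its single ring nitrogen and the same amino group, would address at this carbon. Also open, going by these compounds, is what the amino group contributes on the pyrazine ring itself, which pyrazin-2-yl without the amine would show in a direct comparison with compound 1.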